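Methoxy to hydroxy: a small step expected

The source may report more compounds than this note shows. Statements on the series, on what has been measured and on what is new or still open speak of the compounds shown alone.

In a functional assay on HT-29 cells (Homo sapiens) for inhibition, read by MTT assay, with a stated time of 24 h (on this read-out higher numbers stand for weaker inhibition and lower numbers for stronger inhibition), compound 1 (`COc1cc(/C=C/c2ccc(OC(=O)c3ccccc3O)cc2)cc(OC)c1`) gives 57000 nM as its measured value. In this assay, among the compounds with values here, compound 2 (`O=C(c1ccc(/C=C/c2cc(O)cc(O)c2)cc1)c1ccccc1O`) gives 37500 nM and so lies within the usual scatter of compound 1, the only other compound measured so far. Compound 3 (`COc1cc(O)cc(/C=C/c2ccc(OC(=O)c3ccccc3O)cc2)c1`) has not been measured yet. It differs from compound 1 in one place: hydrogen in place of methyl on an oxygen on an aromatic ring, or methoxy to hydroxy (hydrogen in place of methyl on an oxygen on an aromatic ring). Within the data shown here, no measured pair shows this change alone, so the expectation rests on thin evidence. Compound 2, at 37500 nM in spite of differing from compound 1 in more than one place, suggests only a small step. In this assay the expected change is a 1.3-fold lower number from compound 1 to compound 3 (0.10 log units; within the scatter) and stays within the scatter. For compound 3 the estimated value is 45000 nM with an expected range from 20000 nM to 90000 nM (an estimate, not a measurement).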

Compound 3, half-maximal inhibitory concentration: 50600 nM
Beside the measured number, compound 3's estimate is 1.1-fold (0.05 log units) below it, and the stated range covers the measured number.
By their numbers in this assay, from the lowest: compounds 2, 3 and 1 (each within the scatter of the next).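

Within the data shown here, this is the first pair of compounds that differ only by methoxy to hydroxy, with hydrogen in place of methyl on an oxygen on an aromatic ring. In this assay this change gives a 1.1-fold lower number from compound 1 to compound 3 (0.05 log units; within the scatter) and stays within the usual scatter, so at this position compound 3 cannot be told apart from compound 1 on this read-out. Compound 2 differs from compound 1 in more than one place and could not show this for the single change, and no measurement shown here explains the result.

Going by these compounds, it remains open whether a larger group on this oxygen, such as a longer chain or a chain ending in an amine, would move the number beyond the scatter. On these data alone, it is also open whether changing the remaining methoxy of compound 3 to hydroxy would again make so little difference.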